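From aminoethyl to aminocyclohexyl on a shared core

The source may hold more compounds than are shown below. What is called first, only, known or untested is meant among the compounds shown, and "the series" means these compounds.

Compound 1 `CC(C)c1n[nH]c2c(NCc3ccc(-c4ccccn4)cc3)nc(NCCO)nc12` gives 51 nM
Compound 2 `CC(C)c1n[nH]c2c(NCc3ccc(-c4ccccn4)cc3)nc(NCC(C)(C)O)nc12` gives 24 nM
Compound 3 `CC(C)c1n[nH]c2c(NCc3ccc(-c4ccccn4)cc3)nc(NCCN)nc12` gives 62 nM

These values all come from a functional assay on MCF7 cells (Homo sapiens) for cytotoxicity, read by fluorescence, with a stated time of 72 h (on this read-out higher numbers stand for weaker inhibition and lower numbers for stronger inhibition), and the three compounds differ only in the chain on a nitrogen on an aromatic ring. Compound 3 sits level with compound 1, at a 1.2-fold higher number from compound 1 to compound 3 (0.08 log units; within the scatter). It stands clearly apart from compound 2, at a 2.6-fold higher number from compound 2 to compound 3 (0.41 log units; beyond the scatter).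

The next compound to be tested is compound 4 `CC(C)c1n[nH]c2c(NCc3ccc(-c4ccccn4)cc3)nc(N[C@@H]3CCCC[C@H]3N)nc12`. Its change is 2-aminocyclohexyl in place of 2-aminoethyl on a nitrogen on an aromatic ring, or in words, 2-aminocyclohexyl in place of 2-aminoethyl on a nitrogen on an aromatic ring. Among the measured compounds shown here, no measured compound carries this ring, so no measured step covers the change directly. For the measured compounds named here, the closest guide is the one step that adds carbon to the chain, a 2.1-fold lower number from compound 1 to compound 2 (0.33 log units; beyond the scatter), which is modest. The step that swaps hydroxy for amino, a 1.2-fold higher number from compound 1 to compound 3 (0.08 log units; within the scatter), offers no sign that the amino group alone moves the number. A modest step towards a lower number in this assay is therefore expected, although one within the scatter would be no surprise. The expected step is a 2.5-fold lower number from compound 3 to compound 4 (0.39 log units; beyond the scatter). Compound 4 is estimated at 25 nM, with an expected range from 8 nM to 80 nM.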

Compound 4, half-maximal inhibitory concentration: 295 nM
The estimate for compound 4 lay 12-fold (1.07 log units) below the measured number, outside the stated range (above it).
By their numbers in this assay, from the lowest: compound 2; then compounds 1 and 3 (each within the scatter of the next); then compound 4.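

The ring turns out to matter at this position: in this assay, replacing the open 2-aminoethyl chain with 2-aminocyclohexyl on the same nitrogen gives a 4.8-fold higher number from compound 3 to compound 4 (0.68 log units; beyond the scatter). The earlier compounds shown here suggested that extra carbon on this chain might lower the number, but that held only for compound 2, and compound 4 goes against it, so added carbon alone does not set the direction here. The rise also appears against both hydroxy chains, as a 5.8-fold higher number from compound 1 to compound 4 (0.76 log units; beyond the scatter) and as a 12-fold higher number from compound 2 to compound 4 (1.09 log units; beyond the scatter), while the data offer no measured explanation for it.

The compounds shown leave open whether the rise comes from the ring itself, from its size or from the particular arrangement at the two defined stereocentres, since only this one form of the 2-aminocyclohexyl group appears. A 2-aminocyclopentyl ring, a 2-hydroxycyclohexyl ring or the mirror-image form of the 2-aminocyclohexyl group on the same nitrogen would help separate these possibilities, and a longer open chain such as 4-aminobutyl would show whether the added carbon needs to be in a ring to raise the number.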